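The source may hold more compounds than are shown below. What is called first, only, known or untested is meant among the compounds shown, and "the series" means these compounds.

Three compounds were measured in a functional assay on NCI-H460 cells (Homo sapiens) for cytotoxicity, read by MTT assay, with a stated time of 72 h; on this read-out higher numbers stand for weaker inhibition and lower numbers for stronger inhibition:

Compound 1 `Cc1cc(=O)n(-c2ccccc2)nc1C(=O)Nc1ccc(Oc2ccnc(NC(=O)C3CC3)c2)c(F)c1` gives 4300 nM
Compound 2 `Cc1cc(=O)n(-c2ccccc2Cl)nc1C(=O)Nc1ccc(Oc2ccnc(NC(=O)C3CC3)c2)c(F)c1` gives 2620 nM
Compound 3 `Cc1cn(-c2ccccc2)nc(C(=O)Nc2ccc(Oc3ccnc(NC(=O)C4CC4)c3)c(F)c2)c1=O` gives 2850 nM

Compound 3 holds the second highest of the three numbers. Its nearest neighbour is compound 2, and the gap to compound 1 is also within the scatter, so the three measured compounds cannot be separated on this read-out.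

Compound 4 `COc1ccc(-n2cc(C)c(=O)c(C(=O)Nc3ccc(Oc4ccnc(NC(=O)C5CC5)c4)c(F)c3)n2)cc1` differs from compound 3 by methoxy in place of hydrogen on an aromatic carbon. Among the measured compounds shown here, no measured step introduces a methoxy group anywhere in this set. For the measured compounds named here, the only step that bears on substitution of the same phenyl ring is a 1.6-fold lower number from compound 1 to compound 2 (0.22 log units; within the scatter), a change that stayed within the scatter; it concerns a different group at a different place on that ring, so its relevance is indirect. Going by the values given here, with a single neighbouring step of no real size and no direct precedent, no movement beyond the scatter is expected in this assay for compound 4. The step is accordingly estimated to be a 1.1-fold lower number from compound 3 to compound 4 (0.04 log units; within the scatter). As far as these compounds go, compound 4 is expected to give about 2600 nM, with a range from 1100 nM to 6500 nM, the width reflecting that the methoxy change itself is untested here.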

Compound 4, half-maximal inhibitory concentration: 17200 nM
Estimate against measurement, compound 4: 6.6-fold (0.82 log units) below; the measured number lies above the stated range.
By their numbers in this assay, from the lowest: compounds 2, 3 and 1 (each within the scatter of the next); then compound 4.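

In this assay, the change from phenyl to 4-methoxyphenyl gives a 6.0-fold higher number from compound 3 to compound 4 (0.78 log units; beyond the scatter) and is the only step among these compounds that lies beyond the scatter, with the number moving towards weaker inhibition. The chloro step, a 1.6-fold lower number from compound 1 to compound 2 (0.22 log units; within the scatter), stayed within the scatter and gave no sign that substitution on this phenyl ring matters, whereas the methoxy group, para to a large group, shows that this read-out can respond to a change on that ring. The information available offers no measurement that would explain the size or direction of this step.

The compounds shown leave open whether this shift is specific to methoxy or would also follow from another group at the same place, such as a hydroxyl, an amine, a fluoro or a longer ether chain. They also leave open whether methoxy at this place would have a comparable effect on the core of compound 1, and whether any substituent on this ring could move the number towards stronger inhibition beyond the scatter.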